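Swapping Nitro for Chloro on an Aromatic Ester

A few compounds are considered here, and "the series" means these few. Any claim that something is new, unique, unknown or untested is made for them only; others in the source may bear on it.

Measured so far:
compound 1, `CC1=CC[C@H](C(C)C)c2cc(C)c(OC(=O)c3ccc([N+](=O)[O-])cc3)cc21`: 16.8%
compound 2, `Cc1cc2c(C(C)C)ccc(C)c2cc1OC(=O)c1ccc(C(F)(F)F)cc1`: 16.5%

In a functional assay on U-251 cells (Homo sapiens) for antiproliferative activity, read by sulforhodamine B assay, with a stated time of 48 h, tested at 50 uM (a lower number here means less inhibition, a higher number more inhibition at the concentration tested (going by the name of the read-out)), compound 1 gives 16.8%, and compound 2 gives 16.5%; the two lie within the scatter of each other, so neither stands apart. Compound 3, `CC1=CC[C@H](C(C)C)c2cc(C)c(OC(=O)c3ccc(Cl)cc3)cc21`, keeps the core of compound 1 and differs in one place: chloro in place of nitro on an aromatic carbon. For the measured compounds named here, no step between measured compounds is available to gauge such a change, so only a small shift is expected, downward if any, most likely none beyond the scatter. Compound 3 is expected to give 14%, between 4% and 26%. The expected step is a number 2.8 percentage points lower from compound 1 to compound 3 (within the scatter).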

Compound 3, a percentage reported as inhibition, at one concentration (the size of the read-out at that concentration, not a potency): 25.6%
For compound 3 the middle estimate is 11.6 percentage points below the measured one; low and high end bracket the measured number.
By their numbers in this assay, from the lowest: compounds 2, 1 and 3 (each within the scatter of the next).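

In this assay, for the compounds shown here, putting chloro in place of nitro on this aromatic carbon gives a number 8.8 percentage points higher from compound 1 to compound 3 (within the scatter) and is the first step that can be read at this position. Here, a group of three heavy atoms gives way to a single atom, and the change stays inside the usual scatter. No measured evidence bears on this result. Going by these compounds, whether an amine or a carboxylic acid on this carbon would give a step beyond the scatter remains open. On these data alone, the read-out comes from one concentration, so the potency of compound 1 and compound 3 also remains open.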